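Saturated ring carbon substituent swap: pyrazolylethoxy to thienylacetamido

A few compounds are considered here, and "the series" means these few. Any claim that something is new, unique, unknown or untested is made for them only; others in the source may bear on it.

Compound 3 `Cc1nn(-c2ncnc3nc[nH]c23)c2c1C(OCCn1nccc1C)CC(=O)N2` gives 10 nM in a functional assay on HEK293 cells for agonist activity at G-protein coupled receptor 39 (Homo sapiens), read by scintillation proximity assay and inositol phosphate accumulation, with a stated time of 75 min, in the presence of a further agent that is not named here (a lower number here means that less compound is needed, a higher number that more compound is needed for the effect), and stands level with compound 1 `Cc1nn(-c2ncnc3nc[nH]c23)c2c1C(C(=O)Nc1ccccc1)CC(=O)N2`, which gives 10 nM; together the two are the lowest of the three numbers, with compound 2 `Cc1nn(-c2ncnc3nc[nH]c23)c2c1C(c1ccc(OC(C)C)cc1)CC(=O)N2` at 18 nM. The next compound 4 `Cc1nn(-c2ncnc3nc[nH]c23)c2c1C(NC(=O)Cc1cccs1)CC(=O)N2` carries a group of 9 heavy atoms (6 carbon, 1 nitrogen, 1 oxygen, 1 sulfur; one five-membered aromatic ring with 1 hetero atom) in place of a group of 9 heavy atoms (6 carbon, 2 nitrogen, 1 oxygen; one five-membered aromatic ring with 2 hetero atoms), on a saturated ring carbon. Every measured step at this saturated ring carbon bears on it: a 1.8-fold higher number from compound 1 to compound 2 (0.26 log units; within the scatter), no change at the digits printed from compound 1 to compound 3 (within the scatter) and a 1.8-fold lower number from compound 2 to compound 3 (0.26 log units; within the scatter), each within the scatter despite quite different groups. The expected outcome in this assay is therefore a step no larger than the scatter, with no direction favoured, a 1.2-fold higher number from compound 3 to compound 4 (0.08 log units; within the scatter). Compound 4 is estimated at 12 nM, expected between 5 nM and 30 nM.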

Compound 4, half-maximal effective concentration: 3 nM
Beside the measured number, compound 4's estimate is 4.0-fold (0.60 log units) above it; measured number below the stated range.
By their numbers in this assay, from the lowest: compound 4; then compounds 1, 3 and 2 (each within the scatter of the next).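

In this assay, going by these compounds alone, the (((thiophen-2-yl)methyl)carbonyl)amino group gives the first steps at this saturated ring carbon that lie beyond the scatter: a 3.3-fold lower number from compound 3 to compound 4 (0.52 log units; beyond the scatter) and a 3.3-fold lower number from compound 1 to compound 4 (0.52 log units; beyond the scatter) and a 6.0-fold lower number from compound 2 to compound 4 (0.78 log units; beyond the scatter). All three are modest, but they show that the group at this carbon can move the number, which the steps among compound 1, compound 2 and compound 3 did not show. Nothing measured here accounts for these steps.

Open, going by these compounds, is whether the thiophene ring is needed at all. A plain acetamido group, a free amine or a longer chain between the amide and the ring would test this.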